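Chlorophenyl Ester in Place of the Hemisuccinate

The source may hold more compounds than are shown below. What is called first, only, known or untested is meant among the compounds shown, and "the series" means these compounds.

Of the compounds shown here, three built on a shared core have been measured in a functional assay on MDA-MB-231 cells (Homo sapiens) for antiproliferative activity, read by MTT assay, with a stated time of 72 h; on this read-out lower numbers stand for stronger inhibition and higher numbers for weaker inhibition. Compound 1 `CC1=CCC2C(CC[C@@]2(C)O)C(C)(C)C1CC[C@@H]1[C@@]2(C)CC[C@@H](O)C(C)(C)O[C@@H]2CC[C@]1(C)O` reaches only the limit of the assay, reported as > 50000 nM. Compound 2 `CC1=CC[C@H]2[C@H](CC[C@]2(C)O)C(C)(C)[C@@H]1CC[C@H]1[C@]2(C)CC[C@H](OC(=O)CCC(=O)O)C(C)(C)O[C@H]2CC[C@@]1(C)O` gives 27900 nM in this assay. Compound 3 `CC1=CC[C@H]2[C@@H]1CC=C(C)[C@@H](CC[C@H]1[C@]3(C)CC[C@H](OC(=O)c4ccc(Cl)cc4)C(C)(C)O[C@H]3CC[C@@]1(C)O)C2(C)C` gives 12700 nM in this assay. Of the two plain numbers, compound 2 stands highest, and the gap down to compound 3 lies beyond the usual scatter of this assay.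

Compound 4 `CC1=CC[C@H]2[C@H](CC[C@]2(C)O)C(C)(C)[C@@H]1CC[C@H]1[C@]2(C)CC[C@H](OC(=O)c3ccccc3Cl)C(C)(C)O[C@H]2CC[C@@]1(C)O` differs from compound 2 in a single place: 2-chlorophenyl in place of 2-carboxyethyl on a carbonyl carbon. Among the compounds with values here, no pair of measured compounds isolates this change, so its size can only be expected, not read off. Because compound 3, the other ester in the set, gives 12700 nM, a move away from the 2-carboxyethyl ester toward an aromatic ester is expected to lower the number somewhat, beyond the scatter but not by a large margin. Compound 4 is therefore expected to give 12000 nM in this assay, within a range of 4000 nM to 35000 nM. That estimate means a step of a 2.3-fold lower number from compound 2 to compound 4 (0.37 log units; beyond the scatter).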

Compound 4, half-maximal inhibitory concentration: 24300 nM
For compound 4 the middle estimate is 2.0-fold (0.31 log units) below the measured one, within the range that was stated.
By their numbers in this assay, from the lowest: compounds 3, 4 and 2 (each within the scatter of the next, the first and the last beyond it). At a limit, above all of these: compound 1.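

In this assay, putting 2-chlorophenyl in place of 2-carboxyethyl on a carbonyl carbon gives a 1.1-fold lower number from compound 2 to compound 4 (0.06 log units; within the scatter). Within the data shown here, this is the first direct reading at this position, and it shows that two quite different groups can be exchanged there with the numbers remaining within the scatter of each other: one is an open chain with a hydrogen-bond donor and acceptor, the other a six-membered aromatic ring with neither. The data shown offer no explanation for this result.

Going by these compounds, what remains open is whether any group on this carbonyl carbon separates clearly from these two. A chain carrying an amine, a longer carbon chain or an unsubstituted phenyl would each test that at the same position on the shared core.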